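Bromine added to the hydroxyphenyl hydrazone

A few compounds are considered here, and "the series" means these few. Any claim that something is new, unique, unknown or untested is made for them only; others in the source may bear on it.

Compound 1, `O=C(CSc1nnc(-c2ccncc2)o1)N/N=C/c1ccc(F)cc1`, gives 15700 nM in a functional assay on SW 1116 cells (Homo sapiens) for cytotoxicity, read by MTT assay, with a stated time of 48 h; a higher number here means a weaker inhibitor, a lower number a stronger inhibitor.
Compound 2, `O=C(CSc1nnc(-c2ccncc2)o1)N/N=C/c1ccccc1[N+](=O)[O-]`, gives 30700 nM.
Compound 3, `O=C(CSc1nnc(-c2ccncc2)o1)N/N=C/c1ccccc1O`, gives 7380 nM.

The three compounds share one core and differ only in the aryl group on the carbon with a double bond to nitrogen. Compound 3 stands lowest of the three, and both of its steps lie beyond the scatter: a 2.1-fold lower number from compound 1 to compound 3 (0.33 log units; beyond the scatter) and a 4.2-fold lower number from compound 2 to compound 3 (0.62 log units; beyond the scatter). Between the other two the gap is small: a 2.0-fold higher number from compound 1 to compound 2 (0.29 log units; within the scatter). Compound 4, `O=C(CSc1nnc(-c2ccncc2)o1)N/N=C/c1cc(Br)ccc1O`, keeps the hydroxyphenyl of compound 3 and adds a single atom: bromo in place of hydrogen on an aromatic carbon. Among the compounds with values here, no measured step places a halogen on a ring that already carries the hydroxy group, so nothing bears on this change directly; the only guide is that exchanging one ring substituent for another shifted this assay by modest amounts. For compound 4 the expected step is therefore small, a 1.3-fold lower number from compound 3 to compound 4 (0.13 log units; within the scatter), with no clear direction beyond the scatter. The estimate for compound 4 is 5500 nM, within a range of 2200 nM to 14000 nM.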

Compound 4, half-maximal inhibitory concentration: 8150 nM
Beside the measured number, compound 4's estimate is 1.5-fold (0.17 log units) below it; the measured number falls inside the stated range.
By their numbers in this assay, from the lowest: compounds 3, 4, 1 and 2 (each within the scatter of the next, the first and the last beyond it).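

In this assay, bromo on the aromatic carbon para to a hydroxy group gives a step within the scatter (a 1.1-fold higher number from compound 3 to compound 4 (0.04 log units; within the scatter)), so this place on the hydroxyphenyl ring accepts a bromine with no shift that this assay can resolve. The 5-bromo-2-hydroxyphenyl group stays clearly apart from the 2-nitrophenyl group (a 3.8-fold lower number from compound 2 to compound 4 (0.58 log units; beyond the scatter)), but its step from the 4-fluorophenyl group lies within the scatter (a 1.9-fold lower number from compound 1 to compound 4 (0.28 log units; within the scatter)), whereas the step from compound 1 to compound 3 lay beyond it. Nothing available explains why the bromine leaves the number in place.

As far as these compounds go, whether a methoxy, an amine or a carboxylic acid at this same place would leave the number as bromo does remains open. So does whether bromo behaves alike on a ring without the hydroxy group.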